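From 2-fluorophenyl to pyridin-2-yl on the amide

This account rests on a few compounds, and the source may have more. Where it says the series, first, only, none or still open, it means among the compounds named here.

In an ADME assay on LLC-MK2 cells (Macaca mulatta) for cytotoxicity, read by spectrophotometry and crystal violet staining, with a stated time of 4 days (a higher number here means that more compound is tolerated, a lower number that less compound is tolerated), compound 3 `CC(C)n1ncc2c(C(=O)Nc3ccccc3F)cc(-c3cccs3)nc21` gives 50000 nM. Compound 2 `CC(C)n1ncc2c(C(=O)Nc3ccccn3)cc(C3CC3)nc21` gives 25000 nM, and these two values lie within the scatter of each other. Compound 1 `CC(C)n1ncc2c(C(=O)Nc3c(F)cccc3F)cc(-c3cccs3)nc21` gives > 200000 nM, which is a limit of the assay and not a number.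

Compound 4 `CC(C)n1ncc2c(C(=O)Nc3ccccn3)cc(-c3cccs3)nc21` is still unmeasured. It differs from compound 3 as follows: pyridin-2-yl in place of 2-fluorophenyl on an amide-type nitrogen. In short, pyridin-2-yl stands in place of 2-fluorophenyl on an amide-type nitrogen.

For the measured compounds named here, the only measured step at this group is an at least 4.0-fold lower number from compound 1 to compound 3 (0.60 log units; beyond the scatter), so changes here can move the number. Compound 2 also carries pyridin-2-yl and gives 25000 nM. No step beyond the scatter is therefore expected in this assay, and the expected step is a 1.4-fold lower number from compound 3 to compound 4 (0.15 log units; within the scatter). For compound 4 the estimate is 35000 nM, with a range from 12000 nM to 100000 nM.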

Compound 4, half-maximal cytotoxic concentration: > 200000 nM
Compound 4: only a limit was reported; the forecaster's own chance of this, stated with the estimate: 5%; middle value at least 5.7-fold (0.75 log units) away from the limit.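

In this assay there is an at least 4.0-fold higher number from compound 3 to compound 4 (0.60 log units; beyond the scatter), so the group on the amide nitrogen moves the number even when the fluorine count on a phenyl ring stays the same. The other changed position counts too: there is an at least 8.0-fold higher number from compound 2 to compound 4 (0.90 log units; beyond the scatter), so with pyridin-2-yl on the amide, thiophen-2-yl and cyclopropyl are clearly not equivalent. Compound 4 gives a limit of the assay and not a number, as does compound 1, so the step between them cannot be read: the limit of > 200000 nM in this assay, at which 2 of the 4 values shown sit.

As far as these compounds go, whether pyridin-2-yl truly differs from 2,6-difluorophenyl stays open. So does what an amine or a carboxylic acid on the pyridin-2-yl ring would do to the number.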